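Swapping an amine linker for an ether in a bile acid receptor series

A few compounds are considered here, and "the series" means these few. Any claim that something is new, unique, unknown or untested is made for them only; others in the source may bear on it.

Compound 2 `CN(Cc1ccc(C(=O)O)cc1)c1ccc(OCc2c(-c3c(Cl)cccc3Cl)noc2C2CC2)nc1C(F)(F)F` gives 109% in an assay on isolated protein for agonist activity at Bile acid receptor (Homo sapiens), read by FRET (a higher number here means a larger maximal response, a lower number a smaller maximal response), the highest of the three numbers shown, though compound 1 `CN(Cc1cccc(C(=O)O)c1)c1ccc(OCc2c(-c3c(Cl)cccc3Cl)noc2C2CC2)nc1C(F)(F)F` at 102% lies within the scatter of it; compound 3 `CCN(Cc1ccc(C(=O)O)cc1)c1ccc(OCc2c(-c3c(Cl)cccc3Cl)noc2C2CC2)nc1C(F)(F)F` gives 94%. Compound 4 `O=C(O)c1ccccc1OCc1ccc(OCc2c(-c3c(Cl)cccc3Cl)noc2C2CC2)nc1C(F)(F)F` differs from compound 2 as follows: (2-carboxyphenoxy)methyl in place of (4-carboxybenzyl)(methyl)amino on an aromatic carbon. Among the compounds with values here, two measured steps bear on this change. Moving the carboxyl group gave a number 7 percentage points higher from compound 1 to compound 2 (within the scatter), and adding a methyl at the chain carbon gave a number 15 percentage points lower from compound 2 to compound 3 (beyond the scatter). Neither change altered the maximal response much, so compound 4 is expected to stay a near-full agonist, with a step of a number 14 percentage points lower from compound 2 to compound 4 (beyond the scatter) anticipated. Compound 4 is therefore estimated at 95%, in the range 75% to 115%.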

Compound 4, largest response reached (reported as efficacy), in percent of the reference or control that the assay uses: 91%
Compound 4: the middle estimate sits 4 percentage points above what was measured; the measured number falls inside the stated range.
By their numbers in this assay, from the lowest: compounds 4, 3, 1 and 2 (each within the scatter of the next, the first and the last beyond it).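

At this aromatic carbon, (2-carboxyphenoxy)methyl gives a modest loss against both amine-linked groups in this assay: a number 18 percentage points lower from compound 2 to compound 4 (beyond the scatter), and a number 11 percentage points lower from compound 1 to compound 4 (beyond the scatter). The amine nitrogen is still not needed for a substantial maximal response, as compound 4 gives 91% without it. Nothing available explains the loss. The linker and the carboxyl position change together here, so their contributions remain unseparated. A (4-carboxyphenoxy)methyl group at this carbon would bear directly on that question, as would an amide in place of the carboxylic acid on whether the acid itself matters.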